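Stereocentre inversion in the propanoic acid series

The source may hold more compounds than are shown below. What is called first, only, known or untested is meant among the compounds shown, and "the series" means these compounds.

Three compounds have numbers in a functional assay on CHO cells for antagonist activity at sphingosine 1-phosphate receptor 2 (Homo sapiens), read by GTPgammaS binding; on this read-out lower numbers stand for stronger inhibition and higher numbers for weaker inhibition. Compound 1 `C[C@@H](C(=O)O)c1nn(Cc2cn3cc(OCC4CC4)c(Cl)cc3n2)c2ccccc2c1=O` gives 253 nM. Compound 3 `COc1cc2[nH]c(Cc3nn(CC(=O)O)c(=O)c4ccccc34)nc2cc1Cl` gives 241 nM, which lies within the scatter of compound 1. Compound 2 `COc1cc(OC)c(NC(=O)Cc2cn(C)c3ccccc23)cc1Cl` gives 19200 nM, the highest number of the three and well beyond the scatter from compound 1. Compound 1 thus stands second highest of the three numbers, although it cannot be separated from compound 3.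

Compound 4 `C[C@H](C(=O)O)c1nn(Cc2cn3cc(OCC4CC4)c(Cl)cc3n2)c2ccccc2c1=O` differs from compound 1 as follows: the two compounds have the same atoms and bonds and differ only in configuration as drawn: 1 of 1 stereo elements differ; a stereocentre at a saturated chain carbon is drawn R in compound 1 and S in compound 4. For the measured compounds named here, no measured pair here differs in one place, so the weight of a stereocentre is unknown. Such an inversion can move the number either way; the step from compound 1 to compound 4 is expected to be a 2.4-fold higher number from compound 1 to compound 4 (0.38 log units; beyond the scatter), a modest weakening with broad uncertainty. Compound 4 is estimated at 600 nM, within 150 nM to 3000 nM.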

Compound 4, half-maximal inhibitory concentration: 16 nM
For compound 4 the middle estimate is 38-fold (1.57 log units) above the measured one, and the stated range ends above it.
By their numbers in this assay, from the lowest: compound 4; then compounds 3 and 1 (each within the scatter of the next); then compound 2.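

In this assay, inverting the stereocentre at the saturated chain carbon from R to S gives a 16-fold lower number from compound 1 to compound 4 (1.20 log units; beyond the scatter), so configuration at this position carries large weight in this pair. The earlier compounds shown here included no pair differing in one place and gave no measure of this. The step belongs to the stereocentre alone, because nothing else changes: the fact that compounds 1 and 4 differ only in the configuration as drawn

As far as these compounds go, whether S remains favoured with an ethyl group at the stereocentre, or with an amide replacing the carboxylic acid, stays open. One pair cannot show whether this configurational effect extends to other cores.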